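This account rests on a few compounds, and the source may have more. Where it says the series, first, only, none or still open, it means among the compounds named here.

Working notes on the series. In a functional assay on MCF7 cells (Homo sapiens) for inhibition, read by CCK-8 assay, with a stated time of 48 h (a higher number here means a weaker inhibitor of growth, a lower number a stronger inhibitor of growth), compound 1 `COc1ccccc1CNc1nc(Nc2ccc(N3CCN(C)CC3)cn2)ncc1Cl` gives > 100000 nM, which is a limit of the assay and not a number. Within the data shown here, compound 2 `CC(C)c1cccc(Nc2nc(Nc3ccc(N4CCN(C)CC4)cn3)ncc2Cl)c1` gives 8640 nM, the only true number so far.

Among the measured compounds shown here, the one measured step, an at least 11-fold lower number from compound 1 to compound 2 (1.06 log units; beyond the scatter), is large and beyond the scatter. It puts 3-isopropylphenyl in place of 2-methoxybenzyl on a nitrogen on an aromatic ring.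

Compound 3 `COc1ccc(Nc2nc(Nc3ccc(N4CCN(C)CC4)cn3)ncc2Cl)cc1` changes that same group again: 4-methoxyphenyl in place of 3-isopropylphenyl on a nitrogen on an aromatic ring. In words, 4-methoxyphenyl stands in place of 3-isopropylphenyl on a nitrogen on an aromatic ring. Compound 3 keeps a phenyl group on that nitrogen, as compound 2 does, whereas compound 1 carries a benzyl group there, so a repeat of the size of an at least 11-fold lower number from compound 1 to compound 2 (1.06 log units; beyond the scatter) is not expected. With a single step as a guide, the expectation in this assay is a modest move toward a higher number, with a 1.5-fold higher number from compound 2 to compound 3 (0.18 log units; within the scatter) as the estimated step. For compound 3 the estimated value is 13000 nM, with an expected range from 4000 nM to 45000 nM.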

Compound 3, concentration for 50% growth inhibition: 8450 nM
Beside the measured number, compound 3's estimate is 1.5-fold (0.19 log units) above it, and the stated range covers the measured number.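

Exchanging 3-isopropylphenyl for 4-methoxyphenyl on the nitrogen gives a 1.0-fold lower number from compound 2 to compound 3 (0.01 log units; within the scatter), so in this assay these two substituted phenyl groups cannot be told apart, despite the different substituents at different ring positions. The second comparison, an at least 11-fold lower number from compound 1 to compound 3 (1.07 log units; beyond the scatter), matches the large step already seen with 3-isopropylphenyl, so two different phenyl groups now stand apart from the 2-methoxybenzyl group of compound 1, and the earlier step no longer rests on a single phenyl group. Compound 1 gives > 100000 nM, which is a limit of the assay and not a number, so the true size of both steps from it stays unknown: the limit of > 100000 nM in this assay, at which 1 of the 3 values shown sits.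

With 2-methoxybenzyl as the only benzyl group shown, the compounds leave open whether the gap follows from the extra carbon between the nitrogen and the ring or from the methoxy group's place on it, a question that a 3-isopropylbenzyl or 4-methoxybenzyl group would address. Also open, from the compounds shown here alone, is whether the phenyl ring needs a substituent at all, and how an unsubstituted phenyl, or a phenyl carrying an amine or a carboxylic acid, would compare with compound 3 at 8450 nM.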